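Moving the chain's hydroxy onto the second core

This account rests on a few compounds, and the source may have more. Where it says the series, first, only, none or still open, it means among the compounds named here.

Compound 1 `CCCCCCC#Cc1ccc(S(=O)(=O)Nc2cccc(-c3csc(NC(C)=O)n3)c2)cc1` and compound 2 `CC(=O)Nc1nc(-c2cccc(NS(=O)(=O)c3ccc(C#CCO)cc3)c2)cs1` share one core. In a functional assay on A-375 cells (Homo sapiens) for antiproliferative activity, read by trypan blue exclusion, with a stated time of 48 h, tested at 10 uM (on this read-out lower numbers stand for a stronger effect and higher numbers for a weaker effect at the one concentration tested), compound 1 gives 5.8%, while compound 2 gives 48.8%. The step of a number 43 percentage points higher from compound 1 to compound 2 (beyond the scatter) comes from the change (hydroxy in place of pentyl on a saturated chain carbon bound to a triple-bonded carbon). Compound 3 `CCCCCCC#Cc1cccc(S(=O)(=O)Nc2cccc(-c3csc(NC(C)=O)n3)c2)c1` has the same atoms as compound 1 joined differently; the difference between the two cores is not broken down here. In this assay compound 3 gives only a limit of the assay, < 1% (the limit of < 1% in this assay, at which 1 of the 3 values shown sits). Compound 4 `CC(=O)Nc1nc(-c2cccc(NS(=O)(=O)c3cccc(C#CCO)c3)c2)cs1` differs from compound 3 by the same change, (hydroxy in place of pentyl on a saturated chain carbon bound to a triple-bonded carbon). Compound 4 is therefore expected to move by about as much, a number at least 39 percentage points higher from compound 3 to compound 4 (beyond the scatter), resting on the measured step of a number 43 percentage points higher from compound 1 to compound 2 (beyond the scatter). In this assay compound 4 is estimated at 40%, within 15% to 70%.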

Compound 4, a percentage reported as activity, at one concentration (the size of the read-out at that concentration, not a potency): 45.3%
Beside the measured number, compound 4's estimate is 5.3 percentage points below it, and the stated range covers the measured number.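

Replacing the pentyl with a hydroxy weakens the effect on both cores in this assay, and on the second core the change gives a number at least 44.3 percentage points higher from compound 3 to compound 4 (beyond the scatter), so the direction carries over from one core to the other: the same change on two cores in this assay, a number 43 percentage points higher (beyond the scatter) from compound 1 to compound 2 and a number at least 44.3 percentage points higher (beyond the scatter) from compound 3 to compound 4; the limit leaves it open whether they differ

Compound 3 gives < 1%, which is a limit of the assay and not a number. The two steps therefore point the same way, but their sizes cannot be matched exactly, and two cores do not make a rule for the whole series.

The compounds shown leave open whether losing the long chain or gaining the hydroxy drives the step, since both happen together. A plain methyl, an amine or a carboxylic acid at the same place could help separate these two parts.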